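A few compounds are considered here, and "the series" means these few. Any claim that something is new, unique, unknown or untested is made for them only; others in the source may bear on it.

Working notes on the urea series. In a functional assay on NCI-H460 cells (Homo sapiens) for cytotoxicity, read by MTT assay, with a stated time of 72 h (a higher number here means a weaker inhibitor, a lower number a stronger inhibitor), compound 1 `CN(C)CCNc1nc(-c2ccc(NC(=O)Nc3ccc(F)cc3)cc2)nc2c(Cl)c(Cl)sc12` gives 590 nM. For the measured compounds named here, compound 2 `CN(C)CCNc1nc(-c2ccc(NC(=O)Nc3ccccc3Cl)cc2)nc2c(Cl)c(Cl)sc12` gives 440 nM in this assay, the only measured step being a 1.3-fold lower number from compound 1 to compound 2 (0.13 log units; within the scatter). On the numbers shown, compound 2 stands at the lower of the two values, its one neighbour being compound 1 at a distance within the scatter, so no order between them is established.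

Compound 3 `CN(C)CCNc1nc(-c2ccc(NC(=O)Nc3ccc(Cl)cc3Cl)cc2)nc2c(Cl)c(Cl)sc12` differs from compound 2 by chloro in place of hydrogen on an aromatic carbon. Going by the values given here, no measured pair tests chloro in place of hydrogen on this ring; the single step that bears on the urea aryl group, a 1.3-fold lower number from compound 1 to compound 2 (0.13 log units; within the scatter), was within the scatter. The step from compound 2 to compound 3 in this assay is therefore expected to be small, a 1.1-fold lower number from compound 2 to compound 3 (0.04 log units; within the scatter), with no direction beyond the scatter predicted. Compound 3 is estimated at 400 nM in this assay, with a range from 150 nM to 1100 nM.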

Compound 3, half-maximal inhibitory concentration: 1520 nM
Beside the measured number, compound 3's estimate is 3.8-fold (0.58 log units) below it; the whole stated range lies below it.
By their numbers in this assay, from the lowest: compounds 2 and 1 (each within the scatter of the next); then compound 3.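

Chloro in place of hydrogen, on the aromatic carbon para to a large group, gives the first change at the urea aryl group that lies beyond the scatter in this assay, with a 3.5-fold higher number from compound 2 to compound 3 (0.54 log units; beyond the scatter) as the step. The 2,4-dichlorophenyl group also separates from the 4-fluorophenyl group, with a 2.6-fold higher number from compound 1 to compound 3 (0.41 log units; beyond the scatter) as the step, whereas the 2-chlorophenyl and 4-fluorophenyl groups could not be told apart, so this aryl group is not indifferent to every change. Nothing available on these compounds accounts for the higher number.

Still open, going by these compounds, is whether a methoxy group or an amine on this same carbon would shift the number in the same direction as chloro. Also open, on these data alone, is whether the shift depends on the 2-chloro group already on the ring, or would appear with a 4-chlorophenyl group alone.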